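Swapping Chloromethyl for Prop-1-en-1-yl on the Carbonyl

A few compounds are considered here, and "the series" means these few. Any claim that something is new, unique, unknown or untested is made for them only; others in the source may bear on it.

For the measured compounds named here, in a functional assay on Rec1 cells (Homo sapiens) for inhibition, read by luminescence and CellTiter-Glo, with a stated time of 72 h (on this read-out higher numbers stand for weaker inhibition and lower numbers for stronger inhibition), compound 1 `O=C(CCl)N1CCCC(n2nc(-c3ccc(Oc4ccccc4)cc3)cc2CO)C1` gives 400 nM, the lower of the two numbers measured so far, and compound 2 `O=C(O)c1cc(-c2ccc(Oc3ccccc3)cc2)nn1C1CCCN(C(=O)CCl)C1` gives 2200 nM. Compound 3 `C/C=C/C(=O)N1CCCC(n2nc(-c3ccc(Oc4ccccc4)cc3)cc2CO)C1` places prop-1-en-1-yl in place of chloromethyl on a carbonyl carbon. Going by the values given here, the only measured step, carboxy in place of hydroxymethyl on an aromatic carbon, shows a 5.5-fold higher number from compound 1 to compound 2 (0.74 log units; beyond the scatter). It lies elsewhere in the structure and serves only as a loose gauge of size. A modest rise of similar size is expected, namely a 3.0-fold higher number from compound 1 to compound 3 (0.48 log units; beyond the scatter). For compound 3, the estimated value is 1200 nM, within an expected range of 300 nM to 5000 nM.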

Compound 3, half-maximal inhibitory concentration: 27200 nM
For compound 3 the middle estimate is 23-fold (1.36 log units) below the measured one, and the stated range ends below it.
By their numbers in this assay, from the lowest: compound 1; then compound 2; then compound 3.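

Prop-1-en-1-yl in place of chloromethyl on a carbonyl carbon brings a 68-fold higher number from compound 1 to compound 3 (1.83 log units; beyond the scatter) in this assay, so this position tolerates this change poorly. That step is larger than a 5.5-fold higher number from compound 1 to compound 2 (0.74 log units; beyond the scatter), the change on an aromatic carbon, and it leaves compound 3 with the highest number of the three. Nothing available here accounts for the size of this step.

The compounds shown leave open how a plain vinyl group, a bromomethyl group or a butenyl chain carrying a dimethylamino group would fare on this carbonyl carbon, with the rest of compound 1 unchanged.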